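The compounds below may be only part of what the source reports. "The series", "measured", "known", "first", "only" and "open" are said of these compounds alone.

Measured so far:
compound 1 `CC(=O)c1cc2ccc(OCCCCCn3cc(CNC(=O)CCCCC4CCSS4)nn3)cc2oc1=O` — 20.8%
compound 2 `COc1ccc(-c2cc3ccc(OCCCCCn4cc(CNC(=O)CCCCC5CCSS5)nn4)cc3oc2=O)cc1` — 45.5%
compound 3 `COc1ccc(-c2cc3ccc(OCCCCCn4cc(CNC(=O)CCCCC5CCSS5)nn4)cc3oc2=O)cc1OC` — 50.5%

In a functional assay on PC-12 cells (Rattus norvegicus) for cytotoxicity, read by MTT assay, with stated times of 3 h and 2 h, tested at 10 uM (on this read-out lower numbers stand for a weaker effect and higher numbers for a stronger effect at the one concentration tested), compound 3 has the highest of the three numbers, but compound 2 lies within the scatter of it (a number 5 percentage points higher from compound 2 to compound 3 (within the scatter)); only compound 1 is clearly lower (a number 29.7 percentage points higher from compound 1 to compound 3 (beyond the scatter)). Compound 4 `O=C(CCCCC1CCSS1)NCc1cn(CCCCCOc2ccc3cc(-c4ccc(Br)cc4)c(=O)oc3c2)nn1` differs from compound 3 in one place: 4-bromophenyl in place of 3,4-dimethoxyphenyl on an aromatic carbon. Going by the values given here, no measured step swaps one aryl group for another. Among the compounds with values here, the steps that bear on it are a number 24.7 percentage points higher from compound 1 to compound 2 (beyond the scatter) and a number 29.7 percentage points higher from compound 1 to compound 3 (beyond the scatter), both modest rises when an aryl group replaces acetyl at this carbon, while the methoxy change a number 5 percentage points higher from compound 2 to compound 3 (within the scatter) stayed within the scatter. Compound 4 keeps an aryl group there, so no step beyond the scatter is expected: a number 5.5 percentage points lower from compound 3 to compound 4 (within the scatter). Compound 4 is therefore estimated at 45% in this assay, range 30% to 60%.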

Compound 4, a percentage reported as activity, at one concentration (the size of the read-out at that concentration, not a potency): 48.4%
Compound 4: middle estimate off by 3.4 percentage points, on the low side; the range from low to high includes it.
By their numbers in this assay, from the lowest: compound 1; then compounds 2, 4 and 3 (each within the scatter of the next).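

In this assay, 4-bromophenyl in place of 3,4-dimethoxyphenyl takes the aryl group from 2 hydrogen-bond acceptors to 0, yet the step stays within the scatter (a number 2.1 percentage points lower from compound 3 to compound 4 (within the scatter)), as does bromo in place of methoxy (a number 2.9 percentage points higher from compound 2 to compound 4 (within the scatter)). The gain over acetyl therefore extends to an aryl group without methoxy (a number 27.6 percentage points higher from compound 1 to compound 4 (beyond the scatter)), and none of the three aryl compounds goes against it. No measurement here explains this pattern.

From the compounds shown here alone, whether an amine or a carboxylic acid at this aromatic carbon would match the aryl compounds or compound 1 remains open. Going by these compounds, with one concentration per compound, the numbers speak only to a stronger or weaker effect at that concentration, and how the effect changes at other concentrations remains open.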